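Swapping a sulfonyl acid arm for a vinyl tetrazole

The compounds below may be only part of what the source reports. "The series", "measured", "known", "first", "only" and "open" are said of these compounds alone.

Compound 1 `C[C@H](Oc1ccc2ncc(/C=C/C(N)=O)c(C3CC3)c2c1)c1c(Cl)ccc(F)c1Cl` gives in a physicochemical assay for lipophilicity, using the shake flask method; a lower number here means a more polar compound, a higher number a more lipophilic compound > 5.5, which is a limit of the assay and not a number.
Compound 2 `C[C@H](Oc1ccc2ncc(/C=C/C(=O)NC(CC(=O)O)CC(=O)O)c(C3CC3)c2c1)c1c(Cl)ccc(F)c1Cl` gives 0.4.
Compound 3 `C[C@H](Oc1ccc2ncc(S(=O)(=O)CC(=O)O)c(C3CC3)c2c1)c1c(Cl)ccc(F)c1Cl` gives 2.5.

Compound 3 holds the higher of the two numbers measured, with compound 2 below it. The two measured steps, a number at least 5.10 log units lower from compound 1 to compound 2 (beyond the scatter) and a number at least 3.00 log units lower from compound 1 to compound 3 (beyond the scatter), both attach carboxylic acid groups to compound 1 and both run far downward. Compound 4 `C[C@H](Oc1ccc2ncc(/C=C/c3nn[nH]n3)c(C3CC3)c2c1)c1c(Cl)ccc(F)c1Cl` differs from compound 3 in one place: 2-(2H-tetrazol-5-yl)ethenyl in place of (carboxymethyl)sulfonyl on an aromatic carbon. Going by the values given here, no measured step exchanges one acid-bearing arm for a tetrazole arm, so neither bears directly on this change; a small step is expected. Compound 4 is estimated at 2.8, between 1.8 and 3.8, a step of a number 0.30 log units higher from compound 3 to compound 4 (within the scatter).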

Compound 4, distribution coefficient: 3.7
Beside the measured number, compound 4's estimate is 0.90 log units below it; the measured number falls inside the stated range.
By their numbers in this assay, from the lowest: compound 2; then compound 3; then compound 4. At a limit, above all of these: compound 1.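

In this assay, exchanging (carboxymethyl)sulfonyl for 2-(2H-tetrazol-5-yl)ethenyl on this aromatic carbon gives a number 1.20 log units higher from compound 3 to compound 4 (beyond the scatter), although both arms have the same counts of heavy atoms, hydrogen-bond donors and acceptors. On the double-bonded chain, 2H-tetrazol-5-yl gives a number 3.30 log units higher from compound 2 to compound 4 (beyond the scatter) when it replaces the diacid amide arm and a number at least 1.80 log units lower from compound 1 to compound 4 (beyond the scatter) when it replaces carbamoyl. The reading for compound 1 is a limit of the assay and not a number: the limit of > 5.5 in this assay, at which 1 of the 4 values shown sits.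

On these data alone, whether an amine on the same chain, or a longer chain carrying the tetrazole, would fall nearer compound 3 or compound 4 stays open.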